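The compounds below may be only part of what the source reports. "The series", "measured", "known", "first", "only" and "open" are said of these compounds alone.

In a functional assay on BXPC-3 cells (Homo sapiens) for antiproliferative activity, read by MTT assay, with a stated time of 24 h (on this read-out lower numbers stand for stronger inhibition and higher numbers for weaker inhibition), compound 3 `CCn1c(C(=O)NC2(C(=O)O)CC2)ccc1C(CC)(CC)c1ccc(OCS(=O)(=O)c2ccccc2)c(C)c1` gives > 50000 nM, which is a limit of the assay and not a number. On the same core, compound 1 `CCN(CC)CCNC(=O)c1ccc(C(CC)(CC)c2ccc(OCS(=O)(=O)c3ccccc3)c(C)c2)n1CC` gives 6270 nM and compound 2 `CCn1c(C(=O)N[C@@H](CO)CCCO)ccc1C(CC)(CC)c1ccc(OCS(=O)(=O)c2ccccc2)c(C)c1` gives 16400 nM. Compound 4 `CCn1c(C(=O)N[C@@H](C(=O)O)C(C)C)ccc1C(CC)(CC)c1ccc(OCS(=O)(=O)c2ccccc2)c(C)c1` differs from compound 3 as follows: 1-carboxy-2-methylpropyl in place of 1-carboxycyclopropyl on an amide-type nitrogen. The carboxy group therefore stays on the amide-type nitrogen substituent, while the three-membered ring is lost. Within the data shown here, the relevant measured steps are an at least 7.9-fold higher number from compound 1 to compound 3 (0.90 log units; beyond the scatter) and an at least 3.0-fold higher number from compound 2 to compound 3 (0.48 log units; beyond the scatter), both ending at the only measured compound carrying a carboxy group, with a 2.6-fold higher number from compound 1 to compound 2 (0.42 log units; beyond the scatter) as a smaller change without one. No step beyond the scatter is expected in this assay, and the estimated step is an at least 1.1-fold lower number from compound 3 to compound 4 (0.04 log units; that floor lies within the scatter). The estimate for compound 4 is 45000 nM, with an expected range of 20000 nM to 90000 nM.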

Compound 4, half-maximal inhibitory concentration: 13900 nM
Beside the measured number, compound 4's estimate is 3.2-fold (0.51 log units) above it; the whole stated range lies above it.
By their numbers in this assay, from the lowest: compound 1; then compounds 4 and 2 (each within the scatter of the next). At a limit, above all of these: compound 3.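

In this assay a carboxy group on the amide-type nitrogen is not tied to the limit: the open-chain 1-carboxy-2-methylpropyl shows an at least 3.5-fold lower number from compound 3 to compound 4 (0.55 log units; beyond the scatter) and gives a real number. Compound 3 remains a limit of the assay and not a number: the limit of > 50000 nM in this assay, at which 1 of the 4 values shown sits. The other two steps are a 1.2-fold lower number from compound 2 to compound 4 (0.07 log units; within the scatter) and a 2.2-fold higher number from compound 1 to compound 4 (0.35 log units; beyond the scatter), so this acid sits level with the neutral chain of compound 2 but does not reach the 2-(diethylamino)ethyl amide.

Still open, as far as these compounds go, is whether the three-membered ring alone accounts for the gap, a question for the open-chain 1-carboxy-1-methylethyl. Also open, from the compounds shown here alone, is what the acid itself contributes, a question for the methyl ester of 1-carboxy-2-methylpropyl.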